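The compounds below may be only part of what the source reports. "The series", "measured", "known", "first", "only" and "open" are said of these compounds alone.

Working notes on the series.

Among the compounds with values here, compound 3 `Cc1cc(N2CCC(N)CC2)c(S(C)(=O)=O)cc1C(=O)N=C(N)N` gives 9.8 nM in a functional assay for inhibition of sodium/hydrogen exchanger (Oryctolagus cuniculus); on this read-out higher numbers stand for weaker inhibition and lower numbers for stronger inhibition; it stands second highest of the three numbers so far, with compound 1 `Cc1cc(C2CCC2)c(S(C)(=O)=O)cc1C(=O)N=C(N)N` at 8.2 nM as its nearest neighbour and compound 2 `Cc1cc(-c2ccccc2)c(S(C)(=O)=O)cc1C(=O)N=C(N)N` at 19 nM as its furthest. The step of a 1.2-fold higher number from compound 1 to compound 3 (0.08 log units; within the scatter) remains within the scatter. So does the step of a 1.9-fold lower number from compound 2 to compound 3 (0.29 log units; within the scatter). The three substituents at this position are therefore not separated with confidence, though a 2.3-fold higher number from compound 1 to compound 2 (0.36 log units; beyond the scatter) is a modest step beyond it.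

Compound 4 `Cc1cc(-n2ccnc2)c(S(C)(=O)=O)cc1C(=O)N=C(N)N` differs from compound 3 in one place: 1H-imidazol-1-yl in place of 4-aminopiperidin-1-yl on an aromatic carbon. The nearest comparison is the aromatic ring of compound 2 against the saturated ring of compound 3, a 1.9-fold lower number from compound 2 to compound 3 (0.29 log units; within the scatter), and a 2.3-fold higher number from compound 1 to compound 2 (0.36 log units; beyond the scatter) points the same way. A small shift toward a higher number is therefore expected, a 1.5-fold higher number from compound 3 to compound 4 (0.18 log units; within the scatter), though it may well stay within the scatter. Compound 4 is estimated at 15 nM, with a range from 6 nM to 40 nM.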

Compound 4, half-maximal inhibitory concentration: 23 nM
Beside the measured number, compound 4's estimate is 1.5-fold (0.19 log units) below it, within the range that was stated.
By their numbers in this assay, from the lowest: compounds 1, 3, 2 and 4 (each within the scatter of the next, the first and the last beyond it).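

Replacing 4-aminopiperidin-1-yl with 1H-imidazol-1-yl gives the first step from compound 3 at this position that clears the scatter in this assay (a 2.3-fold higher number from compound 3 to compound 4 (0.37 log units; beyond the scatter)). Within the data shown here, the two aromatic rings are not separated (a 1.2-fold higher number from compound 2 to compound 4 (0.08 log units; within the scatter)), while the step from the cyclobutyl group is the largest so far (a 2.8-fold higher number from compound 1 to compound 4 (0.45 log units; beyond the scatter)). Compound 4, with its aromatic ring, thus stands clear of both saturated-ring compounds, compound 1 and compound 3, whereas compound 2, also aromatic, stands clear only of compound 1.

No evidence on the reason for this shift is at hand.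

From the compounds shown here alone, whether the ring or its amine matters in compound 3 stays open. A plain piperidin-1-yl group and an open-chain dimethylamino group at this position would separate the two.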